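This account rests on a few compounds, and the source may have more. Where it says the series, first, only, none or still open, it means among the compounds named here.

Measured compounds:
compound 1, `COc1ccc2c(=O)c(/C=C/C(=O)NCc3cccc(F)c3)coc2c1` — 26900 nM
compound 2, `Cc1ccccc1NC(=O)/C=C/c1coc2cc(O)ccc2c1=O` — > 100000 nM

Within the data shown here, compound 1 holds the only number in a functional assay on A549 cells (Homo sapiens) for inhibition, read by MTT assay, with a stated time of 48 h; on this read-out lower numbers stand for stronger inhibition and higher numbers for weaker inhibition: in this assay compound 1 gives 26900 nM. Compound 2 reaches only a limit of the assay in this assay, > 100000 nM. The sole further point of reference is therefore (the limit of > 100000 nM in this assay, at which 1 of the 2 values shown sits). Among the measured compounds shown here, the pair of compound 1 and compound 2 differ in more than one place, so their two values show only that one is a number and the other a limit.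

Compound 3 `COc1ccc2c(=O)c(/C=C/C(=O)Nc3ccc(F)cc3)coc2c1` follows from compound 1 by one change: 4-fluorophenyl in place of 3-fluorobenzyl on an amide-type nitrogen. For the measured compounds named here, no measured pair traces this change, so the expected size of the step in this assay rests on the two values alone. A step toward weaker inhibition is expected, of a size that may just pass beyond the scatter, as a 1.9-fold higher number from compound 1 to compound 3 (0.27 log units; within the scatter). Compound 3 is estimated at 50000 nM, within 15000 nM to 150000 nM.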

Compound 3, half-maximal inhibitory concentration: 26800 nM
Estimate against measurement, compound 3: 1.9-fold (0.27 log units) above; the range from low to high includes it.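

In this assay, 4-fluorophenyl in place of 3-fluorobenzyl on the amide-type nitrogen gives a 1.0-fold lower number from compound 1 to compound 3 (0.00 log units; within the scatter) and so leaves the read-out unmoved at this position. Among these compounds, this is the first measured pair on this nitrogen, and it shows that, on the core of compound 1, the fluorinated ring can be carried in either the benzyl or the phenyl form with no step beyond the scatter. Nothing measured here offers a reason why the two forms read alike.

The compounds shown leave open whether a longer chain, such as 2-phenylethyl, or a ring-free group, such as an aminoethyl chain or a carboxylic acid, would shift the value on this nitrogen. They also leave open what the fluorine itself contributes, which an unsubstituted phenyl or benzyl would test.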